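The compounds below may be only part of what the source reports. "The series", "measured", "known", "first", "only" and "open" are said of these compounds alone.

In an ADME assay on microsomes from liver (Homo sapiens) for metabolic stability (on this read-out higher numbers stand for fast clearance and lower numbers for slow clearance), compound 1 (`CCc1ccc(-c2c(-c3nn(C)c4ncnc(N5CC(NC(=O)OC)C5)c34)cnn2C)cc1`) gives 42 mL/min/kg and compound 2 (`Cn1ncc(-c2nn(C)c3ncnc(N4CCC4)c23)c1-c1ncc(C2CC2)cn1`) gives 28 mL/min/kg as two numbers within the usual scatter of each other. Compound 3 (`CCc1ccc(-c2c(-c3nn(C)c4ncnc(N5CCN(C)CC5)c34)cnn2C)cc1`) keeps the core of compound 1 but carries 4-methylpiperazin-1-yl in place of 3-((methoxycarbonyl)amino)azetidin-1-yl on an aromatic carbon. Among the compounds with values here, no measured pair of compounds shows this change on its own, so the data offer only a weak guide. The expected 1.1-fold lower number from compound 1 to compound 3 (0.02 log units; within the scatter) stays within the scatter, with no clear direction. The estimated value for compound 3 is 40 mL/min/kg with an expected range from 20 mL/min/kg to 75 mL/min/kg in this measurement.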

Compound 3, clearance: 60 mL/min/kg
Estimate against measurement, compound 3: 1.5-fold (0.18 log units) below, within the range that was stated.
By their numbers in this assay, from the lowest: compounds 2, 1 and 3 (each within the scatter of the next, the first and the last beyond it).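

In this assay, within the data shown here, putting 4-methylpiperazin-1-yl in place of 3-((methoxycarbonyl)amino)azetidin-1-yl on this aromatic carbon gives the first direct comparison at this position (a 1.4-fold higher number from compound 1 to compound 3 (0.15 log units; within the scatter)). This large exchange of groups, from a four-membered ring with a hydrogen-bond donor to a six-membered ring without one, therefore leaves no clear effect on clearance. Nothing available explains this result.

As far as these compounds go, whether morpholin-4-yl or an open-chain amine such as dimethylamino at this position would give a step beyond the scatter remains open. So does whether the same exchange would act alike on a different core.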